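Carbonyl-linked thiazole replacing the trifluoromethylpyrazolylmethyl group

The compounds below may be only part of what the source reports. "The series", "measured", "known", "first", "only" and "open" are said of these compounds alone.

Three members of the series have numbers in an assay on membranes from uterus for displacement of a labelled ligand from Angiotensin type II receptor (Sus scrofa), with a stated time of 1.5 h; on this read-out higher numbers stand for weaker inhibition and lower numbers for stronger inhibition: compound 1 `CCCCOC(=O)NS(=O)(=O)c1sc(CC(C)C)cc1-c1ccc(C(=O)c2ccnn2C)cc1` gives 3.4 nM, compound 2 `CCCCOC(=O)NS(=O)(=O)c1sc(CC(C)C)cc1-c1ccc(Cn2cnc(C(F)(F)F)c2)cc1` gives 7.3 nM, and compound 3 `CCCCOC(=O)NS(=O)(=O)c1sc(CC(C)C)cc1-c1ccc(Cn2ccc(C(F)(F)F)n2)cc1` gives 9.5 nM. Compound 3 has the highest number of the three; compound 2 lies within the scatter of it, whereas a 2.8-fold higher number from compound 1 to compound 3 (0.45 log units; beyond the scatter) is beyond the scatter. Compound 4 `CCCCOC(=O)NS(=O)(=O)c1sc(CC(C)C)cc1-c1ccc(C(=O)c2nccs2)cc1` differs from compound 3 by (1,3-thiazol-2-yl)carbonyl in place of (3-(trifluoromethyl)-1H-pyrazol-1-yl)methyl on an aromatic carbon. The step that bears on this is a 2.8-fold higher number from compound 1 to compound 3 (0.45 log units; beyond the scatter), which moved from a carbonyl-linked azole to the pyrazolylmethyl group; compound 4 returns to a carbonyl-linked azole, so a step of similar size in the opposite direction is expected, a 2.1-fold lower number from compound 3 to compound 4 (0.32 log units; beyond the scatter). Compound 4 is therefore estimated at 4.5 nM, with a range of 1.8 nM to 11 nM in this assay.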

Compound 4, inhibition constant: 18.6 nM
Beside the measured number, compound 4's estimate is 4.1-fold (0.62 log units) below it; measured number above the stated range.
By their numbers in this assay, from the lowest: compound 1; then compounds 2, 3 and 4 (each within the scatter of the next, the first and the last beyond it).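

A carbonyl link on this aromatic carbon does not by itself give the low number of compound 1: with the carbonyl kept, the change of azole gives a 5.5-fold higher number from compound 1 to compound 4 (0.74 log units; beyond the scatter) and so the attached ring matters here. Set against the trifluoromethyl azole groups, the thiazolyl ketone shows a 2.0-fold higher number from compound 3 to compound 4 (0.29 log units; within the scatter) and a 2.5-fold higher number from compound 2 to compound 4 (0.41 log units; beyond the scatter) so its standing depends on the comparator. No supporting data account for these differences.

Open, going by these compounds, is whether a 1-methyl-1H-imidazol-2-yl or a phenyl group on the carbonyl would match compound 1. Also open, on these data alone, is how a carboxylic acid or an amine would fare at this position.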